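The source may hold more compounds than are shown below. What is called first, only, known or untested is meant among the compounds shown, and "the series" means these compounds.

Measured so far in a toxicity assay on THP-1 cells (Homo sapiens) for inhibition; a higher number here means that more compound is tolerated, a lower number that less compound is tolerated:
- compound 1 `COc1ccc(-c2cnc(NC(=O)c3ccccc3O)n2C)cc1`: > 100000 nM.
- compound 2 `COc1ccc(-c2cnc(NC(=O)c3cccc([N+](=O)[O-])c3)n2C)cc1`: > 100000 nM.
- compound 3 `Cn1c(-c2cccc(C#N)c2)cnc1NC(=O)c1ccc(F)cc1`: > 100000 nM.

Compound 1 returns a reading in this assay that is a limit of the assay, not a number: compound 1 gives > 100000 nM. The same holds for compound 2, whose reading of > 100000 nM is likewise only a limit. Compound 3 also returns only a limit, > 100000 nM. Among the compounds with values here, in consequence, compound 1 cannot be placed against the other two beyond the statement that all three readings sit at the limit of > 100000 nM in this assay, at which 3 of the 3 values shown sit; no ordering among them can be read from the data, and no step between measured compounds is available.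

Compound 4 `COc1ccc(-c2cnc(NC(C)=O)n2C)cc1` differs from compound 1 by methyl in place of 2-hydroxyphenyl on a carbonyl carbon. The change removes the ring that carries the hydroxyl and leaves the amide carbonyl with a methyl.

Because the three measured compounds all rest at the limit of > 100000 nM in this assay, at which 3 of the 3 values shown sit, the step from compound 1 is expected to be none beyond the scatter in this assay, with compound 4 also expected to sit at the limit rather than give a number. The step that the limit leaves unreadable from compound 1 to compound 4 is thus expected to be flat. For compound 4 the estimated value is 150000 nM, within a range of 60000 nM to 400000 nM.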

Compound 4, half-maximal cytotoxic concentration: > 100000 nM
Compound 4: a limit, no number (the forecaster's own chance of this, stated with the estimate: 80%); the middle value does not contradict the limit.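

Compound 1 and compound 4 both return only a limit in this assay, so no step between them can be read, and no new comparison arises: the limit of > 100000 nM in this assay, at which 4 of the 4 values shown sit.

The compounds shown leave open what number any of them would give in this assay, and whether methyl in place of 2-hydroxyphenyl on a carbonyl carbon changes that number at all.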